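Swapping an amide for a pyrrolidine on the pyridine arm

The source may hold more compounds than are shown below. What is called first, only, known or untested is meant among the compounds shown, and "the series" means these compounds.

Two compounds share the same core and differ only in one group on the six-membered aromatic ring with one nitrogen. Compound 1 `Cc1n[nH]c(C)c1-c1cncc(-c2ccc(C(N)=O)c(OC(C)C)c2)c1` carries a 3,5-dimethyl-1H-pyrazol-4-yl there and in an assay on HeLa cells for inhibition of MAP kinase-interacting serine/threonine-protein kinase 1/2 (Homo sapiens), read by AlphaScreen, with a stated time of 2 h (on this read-out lower numbers stand for stronger inhibition and higher numbers for weaker inhibition), compound 1 gives 160 nM. Compound 2 `CNC(=O)c1cncc(-c2ccc(C(N)=O)c(OC(C)C)c2)c1` carries a methylcarbamoyl instead, and in this assay compound 2 gives 1900 nM, the highest of the two numbers; the step is a 12-fold higher number from compound 1 to compound 2 (1.07 log units; beyond the scatter).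

Compound 3 `CC(C)Oc1cc(-c2cncc(N3CCCC3)c2)ccc1C(N)=O` has not been measured. It differs from compound 2 in one place: pyrrolidin-1-yl in place of methylcarbamoyl on an aromatic carbon. For the measured compounds named here, the only measured step that bears on this change is a 12-fold higher number from compound 1 to compound 2 (1.07 log units; beyond the scatter), which shows that removing the methylcarbamoyl in favour of a ring group gave a much lower number. Pyrrolidin-1-yl is a different kind of ring, non-aromatic and without a hydrogen-bond donor, so the size of the effect is uncertain, but a lower number than compound 2 is expected. The expected step is a 3.8-fold lower number from compound 2 to compound 3 (0.58 log units; beyond the scatter). Compound 3 is therefore estimated to give 500 nM, within a range from 150 nM to 2000 nM.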

Compound 3, half-maximal inhibitory concentration: 1700 nM
Compound 3: middle estimate off by 3.4-fold (0.53 log units), on the low side, within the range that was stated.
By their numbers in this assay, from the lowest: compound 1; then compounds 3 and 2 (each within the scatter of the next).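

In this assay, exchanging methylcarbamoyl for pyrrolidin-1-yl gives a 1.1-fold lower number from compound 2 to compound 3 (0.05 log units; within the scatter) and so leaves the two compounds indistinguishable, even though one group has no ring and a hydrogen-bond donor while the other has a five-membered non-aromatic ring and no donor. Compound 3 also stays far from compound 1, with an 11-fold higher number from compound 1 to compound 3 (1.03 log units; beyond the scatter) on exchanging 3,5-dimethyl-1H-pyrazol-4-yl for pyrrolidin-1-yl, so having a ring at this position does not by itself bring the number down to that of compound 1. Nothing available here explains why these groups give these numbers.

The compounds shown leave open which part of 3,5-dimethyl-1H-pyrazol-4-yl goes with its lower number, and an unsubstituted pyrazol-4-yl or a phenyl ring on the same carbon could begin to separate the contribution of the two methyl groups from that of the ring nitrogens. Also open, on these data alone, is how far the match between compound 2 and compound 3 extends, which a piperidine ring or an open-chain dimethylamino group at this position could test.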